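The compounds below may be only part of what the source reports. "The series", "measured", "known", "first", "only" and "open" are said of these compounds alone.

Measured in an assay on THP-1 cells for antagonist activity at Toll-like receptor 8 (Homo sapiens); on this read-out higher numbers stand for weaker inhibition and lower numbers for stronger inhibition:
Compound 1, `Cc1cc(-c2nn(C)c3nc(N)ncc23)cnc1OCC12CCC(N)(CC1)CC2`, gives 1 nM.
Compound 2, `Cn1nc(-c2ccc(OC[C@H]3CC[C@@H](N)CC3)c(F)c2)c2cnc(N)nc21`, gives 20 nM.
Compound 3, `Cc1cc(-c2ccc(OCC34CCC(N)(CC3)CC4)c(F)c2)c2cnc(N)nn12`, gives 40 nM.

Among these three numbers compound 2 stands second highest. Its nearest neighbour is compound 3, whose number is higher by an amount that falls within the usual scatter of repeated measurements, so the two cannot be told apart on this read-out. Compound 1 lies far lower, and that gap is well beyond the scatter, so compound 1 is the stronger inhibitor of the pair. Among the compounds with values here, no two of the measured compounds differ in just one place, so no single structural step among them has a measured effect attached to it.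

Compound 4, `Cn1nc(-c2ccc(OCCCC3CCNCC3)c(F)c2)c2cnc(N)nc21`, has not yet been measured. It is built from compound 2 by a single change: 2-(piperidin-4-yl)ethyl in place of 4-aminocyclohexyl on a saturated chain carbon bound to an oxygen on an aromatic ring. The saturated ring of compound 2 with its amine on the far side gives way to a longer chain whose end carries the nitrogen inside a ring. Within the data shown here, with no measured step to lean on, the expectation rests on compound 2 alone. In this assay the expected step is estimated as a 3.0-fold higher number from compound 2 to compound 4 (0.48 log units; beyond the scatter), a modest move towards weaker inhibition. A result within the scatter of compound 2 would not surprise. Compound 4 is therefore estimated at 60 nM, with a likely range from 15 nM to 300 nM.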

Compound 4, half-maximal inhibitory concentration: 26 nM
Beside the measured number, compound 4's estimate is 2.3-fold (0.36 log units) above it, within the range that was stated.
By their numbers in this assay, from the lowest: compound 1; then compounds 2, 4 and 3 (each within the scatter of the next).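

Within the data shown here, the replacement of 4-aminocyclohexyl by 2-(piperidin-4-yl)ethyl is the first single change with a measured effect in this assay, and it comes out as a 1.3-fold higher number from compound 2 to compound 4 (0.11 log units; within the scatter), so the two compounds cannot be told apart on this read-out. This position, on a saturated chain carbon bound to an oxygen on an aromatic ring, therefore keeps the inhibition within the scatter even though the carbon-only ring with its amine gives way to a ring holding the nitrogen, the entering group has one more heavy atom, and both defined stereocentres are gone. Nothing measured here explains why so large a change in shape leaves the number in place.

Every compound shown carries a nitrogen in the group attached through this oxygen, so what a plain cyclohexyl group or a carboxylic acid would do in its place remains open. Also open, from the compounds shown here alone, is whether the same swap would behave alike on the core of compound 1 or on the core of compound 3.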